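The source may report more compounds than this note shows. Statements on the series, on what has been measured and on what is new or still open speak of the compounds shown alone.

Compound 1 `O=C(NCCCCc1ccccc1)n1cc(-c2ccccc2)oc1=O` gives 90 nM in an assay on isolated protein for inhibition of acid ceramidase (Homo sapiens), read by LC-MS, with a stated time of 1 h; a higher number here means a weaker inhibitor, a lower number a stronger inhibitor; compound 2 `O=C(NCCCCc1ccccc1)n1cc(-c2ccc(F)cc2)oc1=O` gives 185 nM; compound 3 `COc1cc(-c2cn(C(=O)NCCCCc3ccccc3)c(=O)o2)ccc1F` gives 80 nM.

Compound 3 has the lowest number of the three, though its gap to compound 1 is within the scatter, as a 1.1-fold lower number from compound 1 to compound 3 (0.05 log units; within the scatter) shows, while a 2.3-fold lower number from compound 2 to compound 3 (0.36 log units; beyond the scatter) is beyond it. Compound 4 `O=C(NCCCCc1ccccc1)n1cc(-c2cccnc2)oc1=O` differs from compound 3 by pyridin-3-yl in place of 4-fluoro-3-methoxyphenyl on an aromatic carbon. Among the measured compounds shown here, no measured step exchanges the whole ring; the nearest guides are a 1.1-fold lower number from compound 1 to compound 3 (0.05 log units; within the scatter) and a 2.1-fold higher number from compound 1 to compound 2 (0.31 log units; beyond the scatter), both small changes on the same ring with at most modest effect. A modest rise in this assay is therefore expected, a 1.9-fold higher number from compound 3 to compound 4 (0.27 log units; within the scatter), with wide uncertainty. Compound 4 is estimated at 150 nM, between 50 nM and 450 nM.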

Compound 4, half-maximal inhibitory concentration: 70 nM
Estimate against measurement, compound 4: 2.1-fold (0.33 log units) above; the range from low to high includes it.
By their numbers in this assay, from the lowest: compounds 4, 3 and 1 (each within the scatter of the next); then compound 2.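

At this position, next to the ring oxygen, a six-membered aromatic ring with 1 hetero atom is accepted in this assay: a 1.3-fold lower number from compound 1 to compound 4 (0.11 log units; within the scatter) and a 1.1-fold lower number from compound 3 to compound 4 (0.06 log units; within the scatter) both leave the number unchanged within the scatter, even with fewer heavy atoms than 4-fluoro-3-methoxyphenyl. Only the 4-fluorophenyl ring stands apart, with a 2.6-fold lower number from compound 2 to compound 4 (0.42 log units; beyond the scatter), so the ring nitrogen costs nothing here that phenyl would not.

On these data alone, what pyridin-2-yl, pyridin-4-yl or an amine on this ring would give stays open. No evidence at hand accounts for these numbers.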